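The source may report more compounds than this note shows. Statements on the series, on what has been measured and on what is new or still open speak of the compounds shown alone.

Working notes on the cyanoguanidine series. In a functional assay on the whole organism (blood, strain Wistar-Okamoto) with Rattus norvegicus as the target, with a stated time of 5 days (on this read-out lower numbers stand for an effect already at smaller amounts and higher numbers for an effect only at larger amounts of compound), compound 1 `CCC(CC)(CC)/N=C(\NC#N)Nc1cccnc1` gives 1 mg/kg, and compound 2 `CCC(C)(CC)/N=C(\NC#N)Nc1ccncc1` gives 0.5 mg/kg. Among the measured compounds shown here, compound 2 holds the lowest of the two numbers so far, though its gap to compound 1 falls within the scatter, so the pair shows no real order. Compound 3 `CCC(CC)(CC)/N=C(\NC#N)Nc1ccncc1` differs from compound 2 by methyl in place of hydrogen on a saturated chain carbon, two bonds along the chain from a double-bonded nitrogen. For the measured compounds named here, no measured pair isolates this change, so its effect is unknown. The step from compound 2 to compound 3 is expected to stay within the scatter, a 1.4-fold higher number from compound 2 to compound 3 (0.15 log units; within the scatter). Compound 3 is therefore estimated at 0.7 mg/kg, in a range from 0.3 mg/kg to 1.5 mg/kg.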

Compound 3, minimum effective dose: 2.5 mg/kg
For compound 3 the middle estimate is 3.6-fold (0.55 log units) below the measured one; measured number outside the range, above it.
By their numbers in this assay, from the lowest: compounds 2 and 1 (each within the scatter of the next); then compound 3.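

In this assay, methyl in place of hydrogen on a saturated chain carbon, two bonds along the chain from a double-bonded nitrogen, now has a size beyond the scatter, with a 5.0-fold higher number from compound 2 to compound 3 (0.70 log units; beyond the scatter). With the chain held the same, pyridin-4-yl in place of pyridin-3-yl on an amine nitrogen also gives a readable step, with a 2.5-fold higher number from compound 1 to compound 3 (0.40 log units; beyond the scatter). No measured property bears on either step.

Open, going by these compounds, is whether a propyl chain or a hydroxymethyl group at this carbon would continue the rise, and whether the pyridin-3-yl compound responds to the same methyl change.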